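This account rests on a few compounds, and the source may have more. Where it says the series, first, only, none or still open, it means among the compounds named here.

Series notes. Compound 1 `CC(C)NCCS(=O)(=O)NC(=O)c1ccc(Nc2nc(NC3(c4ccc(Cl)cc4)CC3)nc(OCC(F)(F)F)n2)cc1` stands highest of the three measured in a physicochemical assay for permeability, using PAMPA, at pH 7.4 (a lower number here means that the compound crosses the layer more slowly, a higher number that the compound crosses the layer faster), giving 45 nm/s. Compound 2 `CC(C)C(=O)NCCS(=O)(=O)NC(=O)c1ccc(Nc2nc(NC3(c4ccc(Cl)cc4)CC3)nc(OCC(F)(F)F)n2)cc1` gives 13 nm/s in this assay, and compound 3 `O=C(NS(=O)(=O)CCNC(=O)C1CC1)c1ccc(Nc2nc(NC3(c4ccc(Cl)cc4)CC3)nc(OCC(F)(F)F)n2)cc1` gives 1 nm/s. The step of a 3.5-fold lower number from compound 1 to compound 2 (0.54 log units; beyond the scatter) is modest, the step of a 45-fold lower number from compound 1 to compound 3 (1.65 log units; beyond the scatter) is large, and between the two carbonyl-bearing analogues the step of a 13-fold lower number from compound 2 to compound 3 (1.11 log units; beyond the scatter) is also large. Compound 4 `CC(C)OC(=O)NCCS(=O)(=O)NC(=O)c1ccc(Nc2nc(NC3(c4ccc(Cl)cc4)CC3)nc(OCC(F)(F)F)n2)cc1` differs from compound 1 by isopropoxycarbonyl in place of isopropyl on an amine nitrogen. Both measured steps from compound 1 swap the same isopropyl for a group carrying a carbonyl and both lower the number; the one nearest in shape to the change here is a 3.5-fold lower number from compound 1 to compound 2 (0.54 log units; beyond the scatter). A lower number in this assay is therefore expected for compound 4, a step of a 4.5-fold lower number from compound 1 to compound 4 (0.65 log units; beyond the scatter). The estimate for compound 4 is 10 nm/s, with a range of 3 nm/s to 30 nm/s.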

Compound 4, apparent permeability: 71 nm/s
Compound 4: the middle estimate sits 7.1-fold (0.85 log units) below what was measured; the whole stated range lies below it.
By their numbers in this assay, from the lowest: compound 3; then compound 2; then compounds 1 and 4 (each within the scatter of the next).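

On the amine nitrogen, a carbonyl in place of isopropyl does not by itself go with a lower number in this assay since isopropoxycarbonyl gives a 1.6-fold higher number from compound 1 to compound 4 (0.20 log units; within the scatter) and leaves compound 1 and compound 4 within the scatter of each other. The read-out depends strongly on the group on the carbonyl carbon: isopropoxy gives a 5.5-fold higher number from compound 2 to compound 4 (0.74 log units; beyond the scatter) against isopropyl and a 71-fold higher number from compound 3 to compound 4 (1.85 log units; beyond the scatter) against cyclopropyl. Nothing at hand explains these differences.

Open, going by these compounds, is whether other groups on that carbonyl carbon, such as methoxy, tert-butoxy or dimethylamino, behave like isopropoxy. Also open, on these data alone, is whether a longer chain on the amine nitrogen keeps the number of compound 4 71 nm/s in this range.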